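Swapping the Aryl Group on the Triazole Ring

The compounds below may be only part of what the source reports. "The series", "measured", "known", "first", "only" and "open" are said of these compounds alone.

Among the compounds with values here, compound 3 `CC1(C)[C@H]2CC[C@]1(C)N(Cc1cn(-c3ccccc3Cl)nn1)C(=O)C2` gives the lowest number of the three compounds measured so far in a functional assay on SGC-7901 cells (Homo sapiens) for inhibition, read by MTT assay, with a stated time of 24 h (a higher number here means a weaker inhibitor, a lower number a stronger inhibitor), at 220 nM. Compound 1 `Cc1ccc(-n2cc(CN3C(=O)C[C@@H]4CC[C@@]3(C)C4(C)C)nn2)cc1` gives 390 nM and compound 2 `CC1(C)[C@H]2CC[C@]1(C)N(Cc1cn(-c3ccc(F)cc3)nn1)C(=O)C2` gives 500 nM, so all three sit close together. Compound 4 `CC1(C)[C@H]2CC[C@]1(C)N(Cc1cn(-c3cccc(C#N)c3)nn1)C(=O)C2` differs from compound 3 by 3-cyanophenyl in place of 2-chlorophenyl on an aromatic nitrogen. Two earlier steps bear on this kind of aryl exchange: a 1.8-fold lower number from compound 1 to compound 3 (0.25 log units; within the scatter) and a 2.3-fold lower number from compound 2 to compound 3 (0.36 log units; beyond the scatter). Both were small, and the swap from fluoro to methyl gave only a 1.3-fold higher number from compound 1 to compound 2 (0.11 log units; within the scatter). Compound 4 is therefore expected to land near compound 3, with a 1.5-fold higher number from compound 3 to compound 4 (0.16 log units; within the scatter) as the expected step. Compound 4 is estimated at 320 nM, within a range from 130 nM to 800 nM.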

Compound 4, half-maximal inhibitory concentration: 250 nM
Beside the measured number, compound 4's estimate is 1.3-fold (0.11 log units) above it; the measured number falls inside the stated range.
By their numbers in this assay, from the lowest: compounds 3, 4, 1 and 2 (each within the scatter of the next, the first and the last beyond it).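

With a 1.1-fold higher number from compound 3 to compound 4 (0.06 log units; within the scatter) in this assay, this position on the aromatic nitrogen takes 3-cyanophenyl, a group with a triple bond and a hydrogen-bond acceptor, in place of 2-chlorophenyl without a change beyond the scatter. The same holds against the other two aryl groups, with a 2.0-fold lower number from compound 2 to compound 4 (0.30 log units; within the scatter) and with a 1.6-fold lower number from compound 1 to compound 4 (0.19 log units; within the scatter), so the four compounds tolerate different aryl groups here. No measurement shown explains why these numbers stay so close. From the compounds shown here alone, it remains open whether an amine or a carboxylic acid on this aryl ring would keep the number in this range. A longer chain in place of the ring is equally untested by these compounds.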